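A few compounds are considered here, and "the series" means these few. Any claim that something is new, unique, unknown or untested is made for them only; others in the source may bear on it.

Working notes on the series. Among the compounds with values here, in a functional assay on HT-29 cells (Homo sapiens) for inhibition, read by luminescence and CellTiter-Glo, with a stated time of 24 h (a lower number here means that less compound is needed, a higher number that more compound is needed for the effect), compound 3 `CN1C(=S)[C@@H](NC(=O)c2nc(Cc3ccccc3)n(CCCO)n2)COc2ccccc21` stands second highest of the three numbers so far, at 209 nM. Compound 1 `CCn1nc(C(=O)N[C@H]2COc3ccccc3N(C)C2=S)nc1Cc1ccccc1` gives 17 nM in this assay, and compound 2 `CN1C(=S)[C@@H](NC(=O)c2nc(Cc3ccccc3)n(CCCF)n2)COc2ccccc21` gives 4760 nM. The next step goes to compound 4 `CN1C(=S)[C@@H](NC(=O)c2nc(Cc3ccccc3)n(C3COC3)n2)COc2ccccc21`: oxetan-3-yl in place of 3-hydroxypropyl on an aromatic nitrogen.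

All three measured steps change the group on the aromatic nitrogen and so bear on this one. a 12-fold higher number from compound 1 to compound 3 (1.09 log units; beyond the scatter). a 280-fold higher number from compound 1 to compound 2 (2.45 log units; beyond the scatter). a 23-fold lower number from compound 2 to compound 3 (1.36 log units; beyond the scatter). Within the data shown here, the entering oxetan-3-yl keeps one hydrogen-bond acceptor but has no hydrogen-bond donor, which in the counted terms places it with the fluoro end of the step from compound 2 to compound 3 rather than the hydroxy end; the chain is also replaced by a four-membered non-aromatic ring, for which no measured pair gives guidance. A step upward, beyond the scatter, is therefore expected, smaller than the full gap between compound 3 and compound 2: a 3.3-fold higher number from compound 3 to compound 4 (0.52 log units; beyond the scatter) is the estimated step. Compound 4 is expected at 700 nM in this assay, with a range from 150 nM to 3500 nM.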

Compound 4, half-maximal effective concentration: 916 nM
Beside the measured number, compound 4's estimate is 1.3-fold (0.12 log units) below it, within the range that was stated.
By their numbers in this assay, from the lowest: compound 1; then compound 3; then compound 4; then compound 2.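

In this assay, oxetan-3-yl is the only ring on this aromatic nitrogen among the compounds shown, and replacing 3-hydroxypropyl with it gives a 4.4-fold higher number from compound 3 to compound 4 (0.64 log units; beyond the scatter). The ring falls between the other groups, with a 5.2-fold lower number from compound 2 to compound 4 (0.72 log units; beyond the scatter) and a 54-fold higher number from compound 1 to compound 4 (1.73 log units; beyond the scatter), so the four numbers rise in the order ethyl, 3-hydroxypropyl, oxetan-3-yl, 3-fluoropropyl. Nothing measured here accounts for this order.

The compounds shown leave open whether a ring as such is disfavoured on this nitrogen, since they do not separate the ring from the loss of the hydrogen-bond donor; cyclopropyl or 3-hydroxycyclobutyl would bear on that. As far as these compounds go, it also remains open how methyl or 2-hydroxyethyl would compare with ethyl and 3-hydroxypropyl at this position.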